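The source may hold more compounds than are shown below. What is called first, only, known or untested is meant among the compounds shown, and "the series" means these compounds.

For the measured compounds named here, compound 2 `O=Cc1cc(=O)oc2cc(OCc3cccc(Cl)c3)ccc12` is one of two compounds measured in an assay on isolated protein (strain Sprague-Dawley) for inhibition of Amine oxidase [flavin-containing] B (Rattus norvegicus), read by spectrophotometry, with a stated time of 5 min; a higher number here means a weaker inhibitor, a lower number a stronger inhibitor. Compound 1 `CCNc1cc(=O)oc2cc(OCc3cccc(Cl)c3)ccc12` gives 28.2 nM, and compound 2 gives 52.5 nM, the highest of the two numbers, with compound 1 its nearest neighbour. Going by the values given here, the single step between them, a 1.9-fold higher number from compound 1 to compound 2 (0.27 log units; within the scatter), is small. Compound 3 `N#Cc1cc(=O)oc2cc(OCc3cccc(Cl)c3)ccc12` has not yet been measured; it differs from compound 2 by cyano in place of formyl on an aromatic carbon. Among the compounds with values here, only the step from compound 1 to compound 2 bears on this change, and it altered one small group on the same aromatic carbon of the shared core without moving the number beyond the scatter. On that basis the exchange of formyl for cyano is expected to leave this assay essentially unchanged, with no step beyond the scatter in either direction. Compound 3 is therefore estimated to give 40 nM in this assay, with a range from 15 nM to 120 nM. The step from compound 2 to compound 3 implied by this estimate, a 1.3-fold lower number from compound 2 to compound 3 (0.12 log units; within the scatter), is expected to sit within the scatter.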

Compound 3, half-maximal inhibitory concentration: 102 nM
Compound 3: the middle estimate sits 2.6-fold (0.41 log units) below what was measured; measured number inside the range.
By their numbers in this assay, from the lowest: compounds 1, 2 and 3 (each within the scatter of the next, the first and the last beyond it).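

In this assay, the exchange of formyl for cyano on this aromatic carbon stays within the scatter: a 1.9-fold higher number from compound 2 to compound 3 (0.29 log units; within the scatter). Even so, the position is not indifferent to what it carries, since the comparison with the ethylamino compound gives a 3.6-fold higher number from compound 1 to compound 3 (0.56 log units; beyond the scatter), a modest step but the first at this place to pass beyond the scatter. The data available offer no explanation for the difference between these groups.

Going by these compounds, what remains open is whether an unsubstituted amine, a carboxylic acid or a longer alkylamino chain on this carbon would stay within the span set by these three groups or fall outside it. On these data alone, it is also open whether the same steps would hold if the rest of the shared core were changed.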